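A few compounds are considered here, and "the series" means these few. Any claim that something is new, unique, unknown or untested is made for them only; others in the source may bear on it.

For the measured compounds named here, compound 2 `CCCC(Oc1ccc(-n2cc(C(F)(F)F)c(C)n2)cc1)c1ccc(C(=O)NCCC(=O)O)cc1` gives 8300 nM in a functional assay on cells for antagonist activity at Glucagon receptor (Homo sapiens), read by cAMP accumulation, in the presence of a further agent that is not named here (on this read-out higher numbers stand for weaker inhibition and lower numbers for stronger inhibition), the only number among the two values shown for this series. Compound 1 `CCCC(Oc1ccc(-n2cc(OC)cn2)cc1)c1ccc(C(=O)NCCC(=O)O)cc1` reaches only a limit of this assay, > 23000 nM. Going by the values given here, the one step that can be put in numbers, an at least 2.7-fold lower number from compound 1 to compound 2 (0.44 log units; beyond the scatter), rests on that limit of > 23000 nM in this assay, at which 1 of the 2 values shown sits, and shows that changing the groups on the five-membered aromatic ring can move the read-out at least modestly. Compound 3 `CCCC(Oc1ccc(-n2cc3c(n2)CCCC3)cc1)c1ccc(C(=O)NCCC(=O)O)cc1` carries a group of 9 heavy atoms (7 carbon, 2 nitrogen; one five-membered aromatic ring with 2 hetero atoms, one six-membered non-aromatic ring of carbon only) in place of a group of 10 heavy atoms (5 carbon, 2 nitrogen, 3 fluorine; one five-membered aromatic ring with 2 hetero atoms), on an aromatic carbon. Among the compounds with values here, no measured step leads to a fused six-membered non-aromatic ring of this kind, so the only guide is that alterations on this ring have shifted the number beyond the scatter once, and the direction for this new change cannot be read from the data. The expected outcome for compound 3 is 10000 nM, within 3000 nM to 30000 nM. The step this implies, a 1.2-fold higher number from compound 2 to compound 3 (0.08 log units; within the scatter), is expected to stay within the scatter, with wide uncertainty.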

Compound 3, antagonist equilibrium constant: 4200 nM
For compound 3 the middle estimate is 2.4-fold (0.38 log units) above the measured one; measured number inside the range.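

In this assay, a group with a six-membered non-aromatic ring of carbon only, and no fluorine, takes the place of 3-methyl-4-(trifluoromethyl)-1H-pyrazol-1-yl with a 2.0-fold lower number from compound 2 to compound 3 (0.30 log units; within the scatter), so at this position trifluoromethyl is not needed to keep the read-out of compound 2. The same group in place of 4-methoxy-1H-pyrazol-1-yl gives an at least 5.4-fold lower number from compound 1 to compound 3 (0.73 log units; beyond the scatter), a second step beyond the scatter from the methoxy group. The value of compound 1 is a limit, and this step rests on it: the limit of > 23000 nM in this assay, at which 1 of the 3 values shown sits.

All three values remain weak, and whether an amine or a hydroxyl on the six-membered ring would move the number is open. Also open, as far as these compounds go, is how the read-out would respond to a longer chain in place of the propyl chain, or a tetrazole in place of the carboxylic acid.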